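Aryl Piperazine Variation on the Shared Core

A few compounds are considered here, and "the series" means these few. Any claim that something is new, unique, unknown or untested is made for them only; others in the source may bear on it.

Measured so far in an assay on CHO cells for displacement of a labelled ligand from adenosine receptor A1 (Homo sapiens), read by scintillation counting, with a stated time of 90 min, tested at 1 uM, in the presence of a further agent that is not named here; a higher number here means more inhibition at the concentration tested (going by the name of the read-out), a lower number less inhibition:
Compound 1, `CCCn1c(=O)[nH]c2nc(-c3ccc(S(=O)(=O)N4CCN(c5ccc(Br)cc5)CC4)cc3)[nH]c2c1=O`, gives 13%.
Compound 2, `CCCn1c(=O)[nH]c2nc(-c3ccc(S(=O)(=O)N4CCN(c5cccc(Cl)c5)CC4)cc3)[nH]c2c1=O`, gives 21%.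
Compound 3, `CCCn1c(=O)[nH]c2nc(-c3ccc(S(=O)(=O)N4CCN(c5ccccc5F)CC4)cc3)[nH]c2c1=O`, gives 13%.

Compound 3 stands level with compound 1 at the digits given, and the two together are the lowest of the three numbers in this assay. Its nearest neighbour is compound 1 (no change at the digits printed from compound 1 to compound 3 (within the scatter)), its furthest compound 2 (a number 8 percentage points lower from compound 2 to compound 3 (within the scatter)).

Compound 4, `CCCn1c(=O)[nH]c2nc(-c3ccc(S(=O)(=O)N4CCN(c5ccc(C)cc5)CC4)cc3)[nH]c2c1=O`, differs from compound 3 in one place only: 4-methylphenyl in place of 2-fluorophenyl on an amine nitrogen in a ring.

Going by the values given here, the steps that bear on this exchange are the other three swaps of the aryl group on the ring nitrogen: a number 8 percentage points higher from compound 1 to compound 2 (within the scatter), no change at the digits printed from compound 1 to compound 3 (within the scatter) and a number 8 percentage points lower from compound 2 to compound 3 (within the scatter). All of them lie within the scatter, and none gives grounds to expect a step beyond it in this assay for a further aryl change. The expected step is therefore a number 1 percentage points higher from compound 3 to compound 4 (within the scatter). Compound 4 is estimated at 14%, with a range from 3% to 27%.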

Compound 4, a percentage reported as inhibition, at one concentration (the size of the read-out at that concentration, not a potency): 12%
Compound 4: middle estimate off by 2 percentage points, on the high side, and the stated range covers the measured number.
By their numbers in this assay, from the lowest: compounds 4, 1, 3 and 2 (each within the scatter of the next).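

In this assay, 4-methylphenyl gives the aryl groups on the ring nitrogen a member without a halogen, and all its steps stay inside the scatter: a number 1 percentage points lower from compound 3 to compound 4 (within the scatter), a number 9 percentage points lower from compound 2 to compound 4 (within the scatter) and a number 1 percentage points lower from compound 1 to compound 4 (within the scatter). The last of these is a direct exchange on an aromatic carbon, methyl in place of bromo, and it shows that this swap does not separate the two compounds beyond the scatter. No measurement at hand explains these numbers.

Still open, from the compounds shown here alone, is whether any other substituent on this aryl ring, such as a methoxy group, a nitrile or a carboxylic acid, would give a step beyond the scatter. Also open, going by these compounds, is whether replacing the aryl ring with a benzyl or cyclohexyl group on the same ring nitrogen would do so.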